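Piperidine amide in place of carbamate-bearing chain

The source may hold more compounds than are shown below. What is called first, only, known or untested is meant among the compounds shown, and "the series" means these compounds.

Compounds measured in an assay on HEK293 cells for displacement of a labelled ligand from NPC1-like intracellular cholesterol transporter 1 (Homo sapiens); a lower number here means a stronger inhibitor, a higher number a weaker inhibitor:
compound 1, `O=C(CN1CN(c2ccccc2)C2(CCN(C(=O)c3ccc(C4CCCCC4)cc3)CC2)C1=O)NCCCCO`, 10300 nM
compound 2, `CC(C)(C)OC(=O)NC1CCCN(C(=O)CN2CN(c3ccccc3)C3(CCN(C(=O)c4ccc(C5CCCCC5)cc4)CC3)C2=O)C1`, 4400 nM
compound 3, `CC(C)(C)OC(=O)NCNC(=O)CN1CN(c2ccccc2)C2(CCN(C(=O)c3ccc(C4CCCCC4)cc3)CC2)C1=O`, 1700 nM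

Of the three measured compounds, compound 3 gives the lowest number in this assay. Compound 2 stands nearest to it, and compound 1 stands furthest, both beyond the scatter of repeat measurements. Among the compounds with values here, the only single-point step among them runs from compound 1 to compound 3, where a 6.1-fold lower number from compound 1 to compound 3 (0.78 log units; beyond the scatter); the change that brought the (tert-butoxycarbonyl)amino group onto the chain was therefore rewarded in a modest way.

Compound 4, `O=C(CN1CN(c2ccccc2)C2(CCN(C(=O)c3ccc(C4CCCCC4)cc3)CC2)C1=O)N1CCCCC1`, has not yet been measured. It differs from compound 3 in one place: piperidin-1-yl in place of (((tert-butoxycarbonyl)amino)methyl)amino on a carbonyl carbon. The two hydrogen-bond donors and two acceptors of the leaving group are gone, and a six-membered ring with one hetero atom takes their place. The step from compound 1 to compound 3 is the one that bears on this change, since there the (tert-butoxycarbonyl)amino group was added and the number fell; removing the whole carbamate-bearing chain would be expected to move the number back up. Compound 2, which also carries a piperidine ring with a (tert-butoxycarbonyl)amino group, shows a higher number than compound 3. Compound 4 is therefore expected to give 4500 nM, within 1500 nM to 13000 nM, meaning an expected step of a 2.6-fold higher number from compound 3 to compound 4 (0.42 log units; beyond the scatter).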

Compound 4, half-maximal inhibitory concentration: 1100 nM
The estimate for compound 4 lay 4.1-fold (0.61 log units) above the measured number, outside the stated range (below it).
By their numbers in this assay, from the lowest: compounds 4 and 3 (each within the scatter of the next); then compound 2; then compound 1.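

In this assay, the carbonyl carbon whose other neighbour is a saturated chain carbon accepts the plain piperidin-1-yl in place of the whole (((tert-butoxycarbonyl)amino)methyl)amino group, with a 1.5-fold lower number from compound 3 to compound 4 (0.19 log units; within the scatter), so the hydrogen-bond donors and acceptors of the leaving group are not required to keep the number at this level. The unsubstituted ring also stands clear of the two other amides, with a 4.0-fold lower number from compound 2 to compound 4 (0.60 log units; beyond the scatter) when hydrogen replaces (tert-butoxycarbonyl)amino on a saturated ring carbon and with a 9.4-fold lower number from compound 1 to compound 4 (0.97 log units; beyond the scatter) when piperidin-1-yl replaces (4-hydroxybutyl)amino, which shows that a (tert-butoxycarbonyl)amino group is not needed for a number well under that of compound 1. No measurement is available that would account for these differences.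

The compounds shown leave open whether the ring size matters, as a pyrrolidine or an azepane at this carbonyl carbon would show. They also leave open whether the piperidine ring accepts a small substituent other than (tert-butoxycarbonyl)amino, such as a free amine, a hydroxyl or a carboxylic acid.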